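Extending the Alkyne on a Uracil Nucleoside: Ethynyl to Butynyl

A few compounds are considered here, and "the series" means these few. Any claim that something is new, unique, unknown or untested is made for them only; others in the source may bear on it.

Measured compounds:
- compound 1, `C#Cc1cn(C2O[C@H](CO)[C@@H](O)[C@@H]2O)c(=O)[nH]c1=O`: 45 ug/mL
- compound 2, `CCCC/C=C\c1cn([C@H]2C[C@H](O)[C@@H](CO)O2)c(=O)[nH]c1=O`: 361 ug/mL

Of the compounds shown here, two have been tested in a functional assay on L1210 cells (Mus musculus); a higher number here means a weaker inhibitor, a lower number a stronger inhibitor. Compound 1 gives 45 ug/mL, the lower of the two numbers and therefore the stronger inhibitor of the pair. Compound 2 gives 361 ug/mL, a weaker result that lies beyond the usual scatter of repeated measurements. Compound 2 differs from compound 1 in more than one place, so no single structural cause can be read from this pair; the two values simply show that the compound with the longer side chain on the shared core, and a different sugar, is the weaker one.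

The compound now in question is compound 3, `CCC#Cc1cn(C2O[C@H](CO)[C@@H](O)[C@@H]2O)c(=O)[nH]c1=O`. Compared with compound 1 its difference is ethyl in place of hydrogen on a triple-bonded carbon, so the sugar is unchanged and only the alkyne is lengthened. Among the compounds with values here, with no measured step of this exact kind available, the expectation is a modest loss of potency, the step from compound 1 to compound 3 being estimated at a 2.2-fold higher number from compound 1 to compound 3 (0.35 log units; beyond the scatter). Compound 3 is expected to give about 100 ug/mL, within a range of 25 ug/mL to 400 ug/mL.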

Compound 3, concentration for 50% inhibition: > 1000 ug/mL
Compound 3 ended at the assay's limit; the forecaster's own chance of this, stated with the estimate: 5%; middle value at least 10-fold (1.00 log units) from the limit.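

In this assay, compound 3 gives > 1000 ug/mL, which is a limit of the assay and not a number. Going from ethynyl to but-1-yn-1-yl, with the sugar unchanged, is the first change here that sits in one place only, so its effect can be read directly: it is an at least 22-fold higher number from compound 1 to compound 3 (1.34 log units; beyond the scatter), a large loss of potency for the addition of an ethyl group on a triple-bonded carbon. This step gives a minimum size and no upper end, as the value of compound 3 is a limit and the other values shown are numbers: the limit of > 1000 ug/mL in this assay, at which 1 of the 3 values shown sits.

The compounds shown leave open whether a smaller group on the triple-bonded carbon, such as a single methyl, would keep the potency of compound 1, or whether an amine or a hydroxyl at the end of the chain would change the picture. They also leave open whether the same lengthening would cost as much on the different sugar of compound 2, since no pair shown tests that sugar with a triple bond.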